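The source may hold more compounds than are shown below. What is called first, only, known or untested is meant among the compounds shown, and "the series" means these compounds.

The series shares one core and varies only the aromatic ring on the amide-type nitrogen. Compound 1 `O=C(O)CCc1ccc(OCc2nnc(C(=O)Nc3ccccc3)s2)cc1` carries a plain phenyl there; in a functional assay on CHO cells for agonist activity at Free fatty acid receptor 1 (Homo sapiens), read by calcium flux (a higher number here means that more compound is needed for the effect, a lower number that less compound is needed), compound 1 gives 1060 nM. Compound 2 `O=C(O)CCc1ccc(OCc2nnc(C(=O)Nc3ccccc3F)s2)cc1` carries a fluoro on that ring, and in this assay compound 2 gives 580 nM. Compound 3 `Cc1ccccc1NC(=O)c1nnc(COc2ccc(CCC(=O)O)cc2)s1` carries a methyl instead, and in this assay compound 3 gives 1520 nM, the highest of the three numbers: it stands within the scatter of compound 1 and beyond the scatter of compound 2.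

Compound 4 `O=C(O)CCc1ccc(OCc2nnc(C(=O)Nc3ccc(F)c(F)c3)s2)cc1` is not yet measured. Its change from compound 3 is 3,4-difluorophenyl in place of 2-methylphenyl on an amide-type nitrogen, so the methyl leaves and two fluoro enter. Going by the values given here, two measured steps bear on this. Fluoro in place of hydrogen gave a 1.8-fold lower number from compound 1 to compound 2 (0.26 log units; within the scatter), and methyl in place of fluoro gave a 2.6-fold higher number from compound 2 to compound 3 (0.42 log units; beyond the scatter); methyl in place of hydrogen gave a 1.4-fold higher number from compound 1 to compound 3 (0.16 log units; within the scatter). Undoing the methyl-for-fluoro exchange and adding a second fluoro points toward a lower number in this assay, of modest size, with compound 2 as the nearest measured anchor. The number for compound 4 in this assay is therefore expected at 450 nM, within 180 nM to 1100 nM. The expected step is a 3.4-fold lower number from compound 3 to compound 4 (0.53 log units; beyond the scatter).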

Compound 4, half-maximal effective concentration: 580 nM
Compound 4: the middle estimate sits 1.3-fold (0.11 log units) below what was measured; measured number inside the range.
By their numbers in this assay, from the lowest: compounds 2, 4, 1 and 3 (each within the scatter of the next, the first and the last beyond it).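

In this assay, the second fluoro adds nothing that can be read: no change at the digits printed from compound 2 to compound 4 (within the scatter), so 3,4-difluorophenyl and 2-fluorophenyl on the amide-type nitrogen cannot be told apart here. Against plain phenyl, 3,4-difluorophenyl gives a 1.8-fold lower number from compound 1 to compound 4 (0.26 log units; within the scatter), so compounds 1, 2 and 4 form a group in which neither fluoro pattern separates clearly from phenyl, while the only new step beyond the scatter is a 2.6-fold lower number from compound 3 to compound 4 (0.42 log units; beyond the scatter). The position therefore accepts two different fluorophenyl groups at one level, and compound 3 stands apart from those two fluoro compounds, though not from compound 1, so the series gives no graded response to the number of fluoro groups.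

On these data alone, it remains open whether a chloro or methoxy group on the phenyl ring, a pyridine ring or a cyclohexyl group on the amide-type nitrogen would hold this level, and which of the two fluoro groups in compound 4 matters, if either does. No measurement beyond these numbers in the assay is available to account for them.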